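A few compounds are considered here, and "the series" means these few. Any claim that something is new, unique, unknown or untested is made for them only; others in the source may bear on it.

Working notes on the series. The read-out throughout is a functional assay on KB cells (Homo sapiens) for cytotoxicity; a higher number here means a weaker inhibitor, a lower number a stronger inhibitor. Compound 1 `C=C(C)[C@@H]1C[C@@H](CC2(CC=C(C)C)C(=O)C(C(CC(=O)O)c3ccccc3)=C3O[C@@H](C)[C@@H](C)C(=O)C3=C2O)C1(C)C` gives only a limit of the assay here, > 20 ug/mL. Compound 2 `C=C(C)[C@@H]1C[C@@H](CC2(CC=C(C)C)C(=O)C3=C(O)[C@@H](C)[C@@H](C)OC3=C(C(CC(=O)O)c3ccccc3)C2=O)C1(C)C` also gives only a limit in this assay, > 20 ug/mL. For the measured compounds named here, compound 2 thus stands at the assay limit together with the one other value shown, and the numbers allow no order between compound 1 and compound 2 (the limit of > 20 ug/mL in this assay, at which 2 of the 2 values shown sit). Compound 3 `C=C(C)[C@@H]1C[C@@H](CC2(CC=C(C)C)C(=O)C3=C(O)[C@@H](C)[C@H](C)OC3=C(C(CC(=O)O)c3ccccc3)C2=O)C1(C)C` has not yet been measured in this assay. It differs from compound 2 as follows: the two compounds have the same atoms and bonds; at least one stereo element is drawn with a configuration in one of them and without one in the other: 1 of 6 stereo elements differ; a stereocentre at a saturated ring carbon is drawn R in compound 2 and S in compound 3. Going by the values given here, no step between measured compounds exists that bears on this change. Compound 3 is expected to stand where compound 2 stands, so the expected step that the limit leaves unreadable from compound 2 to compound 3 is none beyond the usual scatter, and the assay will most likely again report only a limit. Compound 3 is estimated at 30 ug/mL, with an expected range from 12 ug/mL to 80 ug/mL.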

Compound 3, half-maximal inhibitory concentration: > 20 ug/mL
Compound 3: no number, only a limit (the forecaster's own chance of this, stated with the estimate: 80%); the middle value lies beyond the limit too.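

In this assay, for the compounds shown here, compound 3 gives only the assay limit > 20 ug/mL and compound 2 also stands at a limit, so no step between compound 2 and compound 3 can be read. The compounds shown leave open whether the configuration at the saturated ring carbon matters in this assay for this series.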